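Amino for azido on the sugar ring: compound 4

The source may report more compounds than this note shows. Statements on the series, on what has been measured and on what is new or still open speak of the compounds shown alone.

Measured compounds in a functional assay on L1210 cells (Mus musculus); a lower number here means a stronger inhibitor, a higher number a weaker inhibitor:
Compound 1 `[N-]=[N+]=N[C@H]1C(n2cnc3c(N)nc(Cl)nc32)O[C@H](CO)[C@@H]1O` gives > 120000 nM, a limit of the assay.
Compound 2 `Nc1nc(Cl)nc2c1ncn2C1O[C@H](CO)[C@H](O)[C@H]1N` gives > 120000 nM, a limit of the assay.
Compound 3 `[N-]=[N+]=N[C@H]1C(n2cnc3c(N)nc(F)nc32)O[C@H](CO)[C@@H]1O` gives 100000 nM.

Among the compounds with values here, compound 3 is the only compound of the three with a number in this assay; the other two sit at a limit (the limit of > 120000 nM in this assay, at which 2 of the 3 values shown sit). The step from compound 1 to compound 3, fluoro in place of chloro on an aromatic carbon, reads an at least 1.2-fold lower number from compound 1 to compound 3 (0.07 log units; that floor lies within the scatter).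

Compound 4 `Nc1nc(F)nc2c1ncn2C1O[C@H](CO)[C@H](O)[C@H]1N` differs from compound 3 in one place: amino in place of azido on a saturated ring carbon. The same exchange has been made once before, from compound 1 to compound 2, where it gave a step that the two limits leave unreadable from compound 1 to compound 2. That step therefore gives no readable size, and the fluoro analogue compound 3 lies close to the limit itself.

For compound 4 the step from compound 3 is expected to be a 1.3-fold higher number from compound 3 to compound 4 (0.11 log units; within the scatter), with a fair chance that only a limit is reported. Compound 4 is estimated at 130000 nM, between 50000 nM and 400000 nM.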

Compound 4, half-maximal inhibitory concentration: 120000 nM
Beside the measured number, compound 4's estimate is 1.1-fold (0.03 log units) above it, and the stated range covers the measured number.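

In this assay, within the data shown here, the exchange of azido for amino on this saturated ring carbon can now be read for the first time, on the fluoro compounds: a 1.2-fold higher number from compound 3 to compound 4 (0.08 log units; within the scatter). On this core, then, replacing azido with its 3 heavy atoms by amino with its 1 heavy atom, which also brings in a hydrogen-bond donor, leaves no difference beyond the scatter, and both numbers lie close to the limit of the assay. The fluoro for chloro exchange on the amino compounds gives a number no higher from compound 2 to compound 4 (the limit leaves the size open) and has no size that can be read. Set against the same exchange on the azido compounds, it leaves the comparison open: the same change on two cores in this assay, an at least 1.2-fold lower number (0.07 log units; that floor lies within the scatter) from compound 1 to compound 3 and a number no higher (the limit leaves the size open) from compound 2 to compound 4; the limit leaves it open whether they differ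

Going by these compounds, whether the amino for azido exchange has any size on the chloro compounds stays open, as compound 1 and compound 2 both give only a limit: the limit of > 120000 nM in this assay, at which 2 of the 4 values shown sit. Also open is whether an acetamide or a carboxylic acid on this ring carbon would give a number clearly away from that limit.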